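From methoxy to chloro on an aromatic ring

The source may report more compounds than this note shows. Statements on the series, on what has been measured and on what is new or still open speak of the compounds shown alone.

Measured so far in a functional assay on A549 cells (Homo sapiens) for cytotoxicity, read by CCK-8 assay, with a stated time of 72 h; a higher number here means a weaker inhibitor, a lower number a stronger inhibitor
- compound 1 `COc1ccccc1/C=c1/[nH]c(=O)/c(=C\c2ccccc2OC)n(C)c1=O` gives 7000 nM
- compound 2 `C=CCn1c(=O)/c(=C\c2ccccc2OC)[nH]c(=O)/c1=C\c1ccccc1OC` gives 22400 nM

Compound 1 has the lower of these two numbers, which makes it the stronger inhibitor of the pair. Compound 3 `COc1ccccc1/C=c1\c(=O)[nH]/c(=C/c2ccccc2Cl)c(=O)n1C` has not yet been measured. It differs from compound 1 in one place: chloro in place of methoxy on an aromatic carbon with chloro in place of methoxy on an aromatic carbon, turning a 2-methoxyphenyl into a 2-chlorophenyl.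

Within the data shown here, only one measured step exists, and it bears on this change only loosely. That step is a 3.2-fold higher number from compound 1 to compound 2 (0.51 log units; beyond the scatter) and it is modest, though beyond the scatter. It places vinyl on a saturated chain carbon bound to an aromatic nitrogen, not on an aromatic carbon. Among the measured compounds shown here, no measured pair shows what a change on the aromatic carbon does, so the data give no direction. The expected step is a 1.1-fold lower number from compound 1 to compound 3 (0.03 log units; within the scatter) as an estimate, with no shift beyond the scatter foreseen, although a modest move either way is possible. For compound 3 the estimated value in this assay is 6500 nM with an expected range from 2500 nM to 20000 nM in this test.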

Compound 3, half-maximal inhibitory concentration: 300 nM
For compound 3 the middle estimate is 22-fold (1.34 log units) above the measured one, outside the stated range (below it).
By their numbers in this assay, from the lowest: compound 3; then compound 1; then compound 2.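

In this assay, the aromatic carbon carrying the methoxy group proves to be a sensitive position: exchanging methoxy for chloro on one of the two aromatic rings gives a 23-fold lower number from compound 1 to compound 3 (1.37 log units; beyond the scatter), a large step towards stronger inhibition. Among these compounds, the only earlier step, a 3.2-fold higher number from compound 1 to compound 2 (0.51 log units; beyond the scatter), was modest, ran the other way and came from a change on a chain attached to an aromatic nitrogen, so it gave no sign that a small swap on the aromatic carbon could matter this much. No measurement given here explains why chloro outperforms methoxy at this position.

The compounds shown cannot separate the effect of adding chloro from that of removing methoxy, and plain hydrogen, fluoro, bromo or an amino group on the same carbon would help to tell these apart. Also open, going by these compounds, is whether the 2-methoxyphenyl that compound 3 still carries would respond in the same way if it too became a 2-chlorophenyl.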